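The compounds below may be only part of what the source reports. "The series", "measured", "known", "first", "only" and "open" are said of these compounds alone.

Measured so far:
compound 1, `CCCCNc1nc(N)nc(C)c1CCC(C)(C)O`: 3140 nM
compound 2, `CCCC#Cc1c(C)nc(N)nc1NCCCC`: 5000 nM

In an assay on HEK293 cells for agonist activity at Toll-like receptor 8 (Homo sapiens), read by spectrophotometry (a lower number here means that less compound is needed, a higher number that more compound is needed for the effect), compound 1 gives 3140 nM and compound 2 gives 5000 nM. Among the compounds with values here, compound 2 carries the higher of the two numbers; its only neighbour is compound 1, with a 1.6-fold higher number from compound 1 to compound 2 (0.20 log units; within the scatter).

Compound 3, `CCCCNc1nc(N)nc(C)c1C`, is not yet measured. It differs from compound 2 as follows: methyl in place of pent-1-yn-1-yl on an aromatic carbon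

Within the data shown here, the one measured step at this aromatic carbon, a 1.6-fold higher number from compound 1 to compound 2 (0.20 log units; within the scatter), exchanged one group for another and stayed within the scatter. Among the measured compounds shown here, no measured step cuts the group down to methyl, so there is no direct guide. A higher number is nevertheless expected for compound 3, a 2.0-fold higher number from compound 2 to compound 3 (0.30 log units; within the scatter), with the estimate 10000 nM in the range 3000 nM to 40000 nM in this assay.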

Compound 3, half-maximal effective concentration: 3280 nM
The estimate for compound 3 lay 3.0-fold (0.48 log units) above the measured number; the range from low to high includes it.
By their numbers in this assay, from the lowest: compounds 1, 3 and 2 (each within the scatter of the next).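

In this assay, cutting the group on this aromatic carbon down to methyl gives a 1.5-fold lower number from compound 2 to compound 3 (0.18 log units; within the scatter) and so stays within the scatter. Hydrogen in place of 2-hydroxy-2-methylpropyl on the saturated chain carbon gives a 1.0-fold higher number from compound 1 to compound 3 (0.02 log units; within the scatter) as well, so neither the 3-hydroxy-3-methylbutyl group nor pent-1-yn-1-yl separates from plain methyl here. No measurement at hand explains this flat result. From the compounds shown here alone, whether an amine, a carboxylic acid or a phenyl ring at this aromatic carbon would give a step beyond the scatter remains open.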